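Removing one methoxy from the trimethoxy analogue

The source may hold more compounds than are shown below. What is called first, only, known or untested is meant among the compounds shown, and "the series" means these compounds.

Compound 2 `COc1cc(-c2cc(/C=C/C(=O)c3ccc(N)cc3)[nH]n2)cc(OC)c1OC` gives -69% in a functional assay on UACC-62 cells (Homo sapiens) for cytotoxicity, read by sulforhodamine B assay, with a stated time of 48 h, tested at 10 uM (a lower number here means a stronger effect, a higher number a weaker effect of the compound at the concentration tested), the second highest of the three numbers measured. Compound 1 `COc1ccc(-c2cc(/C=C/C(=O)c3ccc(N)cc3)[nH]n2)cc1` gives -89% in this assay, and compound 3 `COc1cc(-c2cc(/C=C/C(=O)c3ccc(F)c(F)c3)[nH]n2)cc(OC)c1OC` gives -13%. Among the measured compounds shown here, the one step recorded, a number 56 percentage points higher from compound 2 to compound 3 (beyond the scatter), concerns the group on the carbonyl carbon and does not touch the change now considered. Compound 4 `COc1ccc(-c2cc(/C=C/C(=O)c3ccc(N)cc3)[nH]n2)cc1OC` differs from compound 2 by hydrogen in place of methoxy on an aromatic carbon. For the measured compounds named here, no single-change step informs this; the values of compound 1 and compound 2 show only that fewer methoxy groups on that ring went with a lower number, a comparison that spans two changes at once. Compound 4 is therefore expected to sit between them, with a number 11 percentage points lower from compound 2 to compound 4 (beyond the scatter) modest and downward, estimated at -80% within -95% to -60%.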

Compound 4, a percentage reported as activity, at one concentration (the size of the read-out at that concentration, not a potency): 3%
Compound 4: middle estimate off by 83 percentage points, on the low side; measured number above the stated range.
By their numbers in this assay, from the lowest: compound 1; then compound 2; then compound 3; then compound 4.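

In this assay, hydrogen in place of methoxy gives a number 72 percentage points higher from compound 2 to compound 4 (beyond the scatter), while methoxy in place of hydrogen gives a number 92 percentage points higher from compound 1 to compound 4 (beyond the scatter). The number therefore does not follow the count of methoxy groups across compound 1, compound 2 and compound 4, and the result of changing this position depends on the other methoxy groups on that ring. No measurement available here accounts for this reversal.

Open, on these data alone, is whether a hydroxyl or an ethoxy group at this position would behave like methoxy or hydrogen. Also open, as far as these compounds go, is whether the reversal persists with 3,4-difluorophenyl on the carbonyl carbon.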